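An Ethoxy Group in Place of Nitro

This account rests on a few compounds, and the source may have more. Where it says the series, first, only, none or still open, it means among the compounds named here.

In a functional assay, with a stated time of 10 min (a higher number here means a weaker inhibitor, a lower number a stronger inhibitor), compound 1 `O=c1cc(/C=C/c2ccccc2)occ1O` gives 2250 nM and compound 2 `O=c1cc(/C=C/c2ccc([N+](=O)[O-])cc2)occ1O` gives 1700 nM. Among the compounds with values here, these two values lie within the scatter of each other, so compound 2 stands level with compound 1 on the only numbers available. Compound 3 `CCOc1ccc(/C=C/c2cc(=O)c(O)co2)cc1` keeps the shared core and differs from compound 2 as follows: ethoxy in place of nitro on an aromatic carbon. In words, it has ethoxy in place of nitro on an aromatic carbon. Within the data shown here, only one measured step bears on this change: a 1.3-fold lower number from compound 1 to compound 2 (0.12 log units; within the scatter), the replacement of hydrogen by nitro, which stays within the scatter. Among the measured compounds shown here, no measured compound yet carries ethoxy, so the evidence is thin. On that single step, no change beyond the scatter is expected in this assay, and the expected step is a 1.2-fold higher number from compound 2 to compound 3 (0.07 log units; within the scatter). Compound 3 is estimated at 2000 nM, with an expected range of 900 nM to 4500 nM.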

Compound 3, half-maximal inhibitory concentration: 4210 nM
The estimate for compound 3 lay 2.1-fold (0.32 log units) below the measured number; the measured number falls inside the stated range.
By their numbers in this assay, from the lowest: compounds 2, 1 and 3 (each within the scatter of the next, the first and the last beyond it).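

In this assay, this position on the aromatic ring now gives its first step beyond the scatter, a modest one, for ethoxy in place of nitro (a 2.5-fold higher number from compound 2 to compound 3 (0.39 log units; beyond the scatter)). Ethoxy in place of hydrogen stays within the scatter (a 1.9-fold higher number from compound 1 to compound 3 (0.27 log units; within the scatter)), so at this position only the pair of nitro and ethoxy is separated, while each of them stands level with hydrogen. No further data are available to explain the difference between nitro and ethoxy.

The compounds shown leave open whether a different group at this position, such as an amine, a carboxylic acid or a longer chain like butoxy, would shift the number further in either direction. They also leave open how ethoxy would behave elsewhere on the ring, as every substituent shown sits para to a large group.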